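The source may report more compounds than this note shows. Statements on the series, on what has been measured and on what is new or still open speak of the compounds shown alone.

Compound 3 `CC(C)OC(=O)N1CCC(COc2ccc(N3CCN(S(=O)(=O)C4CCCCC4)CC3)nc2)CC1` gives 200 nM in a functional assay on CHO-K1 cells for agonist activity at Glucose-dependent insulinotropic receptor (Homo sapiens), read by a luciferase reporter, with a stated time of 5 h (on this read-out higher numbers stand for an effect only at larger amounts of compound and lower numbers for an effect already at smaller amounts), the lowest of the three numbers, although its steps to compound 1 `CC(C)OC(=O)N1CCC(COc2ccc(N3CCN(S(=O)(=O)C(C)C)CC3)nc2)CC1`, which gives 300 nM, and to compound 2 `COCCS(=O)(=O)N1CCN(c2ccc(OCC3CCN(C(=O)OC(C)C)CC3)cn2)CC1`, which gives 300 nM, both lie within the scatter. Every measured step in the set changes the group on the sulfonyl sulfur: no change at the digits printed from compound 1 to compound 2 (within the scatter), a 1.5-fold lower number from compound 1 to compound 3 (0.18 log units; within the scatter) and a 1.5-fold lower number from compound 2 to compound 3 (0.18 log units; within the scatter). Compound 4 `CC(C)OC(=O)N1CCC(COc2ccc(N3CCN(S(=O)(=O)c4cccnc4)CC3)nc2)CC1` alters the same position: pyridin-3-yl in place of cyclohexyl on a sulfonyl sulfur. Among the measured compounds shown here, no measured step brings an aromatic ring or a hydrogen-bond acceptor to this sulfur, so the bearing steps argue only that this position tolerates variation without a shift beyond the scatter; a step of a 1.3-fold higher number from compound 3 to compound 4 (0.10 log units; within the scatter) is therefore expected. Compound 4 is estimated at 250 nM, within 100 nM to 600 nM.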

Compound 4, half-maximal effective concentration: 2000 nM
The estimate for compound 4 lay 8.0-fold (0.90 log units) below the measured number, and the stated range ends below it.
By their numbers in this assay, from the lowest: compounds 3, 1 and 2 (each within the scatter of the next); then compound 4.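

The sulfonyl sulfur is less tolerant than isopropyl, 2-methoxyethyl and cyclohexyl suggested: pyridin-3-yl gives a 10-fold higher number from compound 3 to compound 4 (1.00 log units; beyond the scatter) and also a 6.7-fold higher number from compound 1 to compound 4 (0.82 log units; beyond the scatter) and a 6.7-fold higher number from compound 2 to compound 4 (0.82 log units; beyond the scatter), each beyond the scatter. Cyclohexyl and pyridin-3-yl have the same heavy-atom count, so that count does not separate compound 3 from compound 4. Nothing available assigns the shift to the ring nitrogen or to the aromatic ring.

Phenyl on this sulfur would separate those two features, and whether it tracks cyclohexyl or pyridin-3-yl remains open.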